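The compounds below may be only part of what the source reports. "The series", "measured", "known", "first", "only" and "open" are said of these compounds alone.

Measured so far:
compound 1 `CCOC(=O)c1cnn(-c2nc(-c3cccs3)c(C#N)c(=O)n2C)c1N` — 79 ug/mL
compound 2 `CSc1nc(-c2ccc(N(C)C)cc2)c(C#N)c(=O)n1C` — 78 ug/mL

In a functional assay, with a stated time of 20 min (a higher number here means a weaker inhibitor, a lower number a stronger inhibitor), compound 1 gives 79 ug/mL, the higher of the two numbers recorded, while compound 2 gives 78 ug/mL; the two values lie within the scatter of each other, and since the two structures differ in more than one place, no single step can be read from them.

Compound 3 `CCOC(=O)c1cnn(-c2nc(-c3ccco3)c(C#N)c(=O)n2C)c1N` differs from compound 1 in one place: furan-2-yl in place of thiophen-2-yl on an aromatic carbon. For the measured compounds named here, no measured pair shows this change, so the data give no direction for it. For compound 3 the expected step of a 1.0-fold higher number from compound 1 to compound 3 (0.01 log units; within the scatter) is small, no more than the scatter in either direction. Compound 3 is therefore estimated at 80 ug/mL, with a range from 40 ug/mL to 160 ug/mL, the width reflecting the absence of any measured step of this kind.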

Compound 3, half-maximal inhibitory concentration: 91 ug/mL
Compound 3: the middle estimate sits 1.1-fold (0.06 log units) below what was measured; low and high end bracket the measured number.
By their numbers in this assay, from the lowest: compounds 2, 1 and 3 (each within the scatter of the next).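

In this assay, furan-2-yl in place of thiophen-2-yl on the aromatic carbon next to the ring nitrogen and ortho to a cyano group gives a 1.2-fold higher number from compound 1 to compound 3 (0.06 log units; within the scatter). For the compounds shown here, this is the first single-place comparison, and it shows that this exchange of one five-membered aromatic ring with 1 hetero atom for another, with the same heavy-atom count, does not move the number beyond the scatter. Nothing available bears on the reason for this result.

Going by these compounds alone, compound 2 differs from the other two compounds in more than one place, so no step involving it can be read. The compounds shown leave open whether a group of a different kind on this carbon, such as an amine or an open alkyl chain, would shift the number beyond the scatter.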